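Amide-for-urea swap on the shared core of compound 2

This account rests on a few compounds, and the source may have more. Where it says the series, first, only, none or still open, it means among the compounds named here.

Compound 2 `COc1cc(-c2nn(-c3cccc(NC(=O)Nc4ccc(Cl)c(Cl)c4)c3)cc2-c2ccncc2)ccc1Cl` is the starting point. In a functional assay on HCT-116 cells (Homo sapiens) for inhibition, read by sulforhodamine B assay, with a stated time of 48 h (a higher number here means a weaker inhibitor of growth, a lower number a stronger inhibitor of growth), compound 2 gives 1210 nM; compound 3 `O=C(Nc1cccc(-n2cc(-c3ccncc3)c(-c3ccc(Cl)c(O)c3)n2)c1)Nc1ccc(Cl)c(Cl)c1` gives 1190 nM and compound 1 `COc1cc(-c2nn(-c3cccc(NC(=O)c4cccc(C(F)(F)F)c4)c3)cc2-c2ccncc2)ccc1Cl` gives 1670 nM, both within the scatter of compound 2. Compound 4 `COc1cc(-c2nn(-c3cccc(NC(=O)c4ccc(Cl)c(C(F)(F)F)c4)c3)cc2-c2ccncc2)ccc1Cl` is not yet measured; it differs from compound 2 by 4-chloro-3-(trifluoromethyl)phenyl in place of (3,4-dichlorophenyl)amino on a carbonyl carbon. The step bearing on this is the reverse of the change from compound 1 to compound 2, where a 1.4-fold lower number from compound 1 to compound 2 (0.14 log units; within the scatter); the step of a 1.0-fold lower number from compound 2 to compound 3 (0.01 log units; within the scatter) concerns a different place. Since that earlier step stayed within the scatter, no change beyond the scatter is expected for compound 4, with a 1.2-fold higher number from compound 2 to compound 4 (0.09 log units; within the scatter). Compound 4 is therefore estimated at 1500 nM, in the range 700 nM to 3200 nM.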

Compound 4, concentration for 50% growth inhibition: 2490 nM
Beside the measured number, compound 4's estimate is 1.7-fold (0.22 log units) below it; the measured number falls inside the stated range.
By their numbers in this assay, from the lowest: compounds 3, 2, 1 and 4 (each within the scatter of the next, the first and the last beyond it).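

In this assay, among the compounds shown here, there is a 2.1-fold higher number from compound 2 to compound 4 (0.31 log units; beyond the scatter) and this is the first step on the carbonyl carbon to pass beyond the scatter, though only modestly. The chloro on the aromatic carbon gives a 1.5-fold higher number from compound 1 to compound 4 (0.17 log units; within the scatter) and so does not by itself separate the two amides, which leaves compound 1 within the scatter of both neighbours. Nothing given here accounts for the shift. Still open, as far as these compounds go, is how the amide would read with a dimethylamino group or a carboxylic acid in place of the chloro on that phenyl ring.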